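This account rests on a few compounds, and the source may have more. Where it says the series, first, only, none or still open, it means among the compounds named here.

Measured compounds and values:

- Compound 1, `Nc1ccc(Oc2cccc(NCc3cccc(OC(F)(F)F)c3)c2)cc1N`: > 15000 nM
- Compound 2, `Nc1ccc(Oc2cccc(NS(=O)(=O)c3cccc(C(F)(F)F)c3)c2)cc1N`: > 15000 nM
- Compound 3, `O=c1[nH]c2ccc(Oc3cccc(NCc4cccc(OC(F)(F)F)c4)c3)cc2[nH]1`: 10200 nM

All three were tested in a functional assay on PLC5 cells (Homo sapiens) for inhibition, read by MTT assay, with a stated time of 24 h; a higher number here means a weaker inhibitor, a lower number a stronger inhibitor. For compound 1 the value > 15000 nM is a limit of the assay, not a number. For compound 2 the value > 15000 nM is likewise a limit, as noted in the limit of > 15000 nM in this assay, at which 2 of the 3 values shown sit. Compound 3 gives a measured value of 10200 nM in this assay.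

Compound 3 arises from compound 1 by a group of 10 heavy atoms (7 carbon, 2 nitrogen, 1 oxygen; one five-membered aromatic ring with 2 hetero atoms, one six-membered aromatic ring of carbon only) in place of a group of 8 heavy atoms (6 carbon, 2 nitrogen; one six-membered aromatic ring of carbon only), on an oxygen on an aromatic ring. The step this made in this assay is an at least 1.4-fold lower number from compound 1 to compound 3 (0.16 log units; that floor lies within the scatter), so it reaches only the bottom edge of what can be resolved. The difference between the cores of compound 1 and compound 2 is not broken down here.

Compound 4, `O=c1[nH]c2ccc(Oc3cccc(NS(=O)(=O)c4cccc(C(F)(F)F)c4)c3)cc2[nH]1`, has not yet been measured. It arises from compound 2 by the same change, (a group of 10 heavy atoms (7 carbon, 2 nitrogen, 1 oxygen; one five-membered aromatic ring with 2 hetero atoms, one six-membered aromatic ring of carbon only) in place of a group of 8 heavy atoms (6 carbon, 2 nitrogen; one six-membered aromatic ring of carbon only), on an oxygen on an aromatic ring). In this assay compound 4 is expected to sit near the boundary of the measurable range, with an estimated step of an at least 1.3-fold lower number from compound 2 to compound 4 (0.13 log units; that floor lies within the scatter), resting on the step from compound 1 to compound 3 an at least 1.4-fold lower number from compound 1 to compound 3 (0.16 log units; that floor lies within the scatter) and on compound 2 being a limit > 15000 nM. The estimate for compound 4 is 11000 nM, with a range from 5000 nM to 30000 nM.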

Compound 4, half-maximal inhibitory concentration: 11500 nM
The estimate for compound 4 lay 1.0-fold (0.02 log units) below the measured number, and the stated range covers the measured number.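

In this assay, carrying the change to the sulfonamide-bearing core gives an at least 1.3-fold lower number from compound 2 to compound 4 (0.11 log units; that floor lies within the scatter), and on this core too the group with the five-membered aromatic ring yields a measured number where 3,4-diaminophenyl gives only a limit. Set beside the earlier step, the result reads as follows: the same change on two cores in this assay, an at least 1.4-fold lower number (0.16 log units; that floor lies within the scatter) from compound 1 to compound 3 and an at least 1.3-fold lower number (0.11 log units; that floor lies within the scatter) from compound 2 to compound 4; the limit leaves it open whether they differ. This shows that both cores give a measured number after the change, but it does not show the true size of either step, nor that the change has a real or equal effect on the two cores, and the data stop at this limit: the limit of > 15000 nM in this assay, at which 2 of the 4 values shown sit.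

Open, going by these compounds, is whether a single amine in place of 3,4-diaminophenyl would also give a measured number in this assay. Also open, on these data alone, is whether the change would carry over to a core with an amide as the link, or with a nitrile or a carboxylic acid in place of trifluoromethyl or trifluoromethoxy.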